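Triazole-linked cinnamic acids: a methoxyphenyl for a fluorophenyl

The source may hold more compounds than are shown below. What is called first, only, known or untested is meant among the compounds shown, and "the series" means these compounds.

This account follows a small set of cinnamic acids that share one core and differ only in the aryl group carried on an aromatic nitrogen of the triazole. Compound 1 `COc1ccc(/C=C\C(=O)O)c(OCc2cn(-c3ccc(NC(C)=O)cc3)nn2)c1CC=C(C)C` bears an acetamidophenyl there, compound 2 `COc1ccccc1-n1cc(COc2c(/C=C\C(=O)O)ccc(OC)c2CC=C(C)C)nn1` a 2-methoxyphenyl, and compound 3 `COc1ccc(/C=C\C(=O)O)c(OCc2cn(-c3ccccc3F)nn2)c1CC=C(C)C` a 2-fluorophenyl. In a functional assay on A549 cells (Homo sapiens) for cytotoxicity, read by MTT assay, with a stated time of 24 h (on this read-out lower numbers stand for stronger inhibition and higher numbers for weaker inhibition), compound 2 gives 43000 nM, whereas compound 1 gives "not determined" (no result reported) and compound 3 gives "not determined" (no result reported), so compound 3 has no number to stand on, and neither has its nearest neighbour in the set.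

Compound 4 `COc1cccc(-n2cc(COc3c(/C=C\C(=O)O)ccc(OC)c3CC=C(C)C)nn2)c1` has not yet been tested. It differs from compound 3 by 3-methoxyphenyl in place of 2-fluorophenyl on an aromatic nitrogen. Among the compounds with values here, no measured pair in this assay shows what such a swap does, and with compound 3 itself unreported, the only anchor is compound 2, whose aryl group likewise carries a single methoxy group. From that anchor compound 4 is expected to be weak in this assay, with an estimated half-maximal inhibitory concentration of 40000 nM and a plausible range from 12000 nM to 120000 nM, with a fair chance that only a limit is reported.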

Compound 4, half-maximal inhibitory concentration: 42700 nM
The estimate for compound 4 lay 1.1-fold (0.03 log units) below the measured number, and the stated range covers the measured number.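

In this assay, within the data shown here, the change from 2-methoxyphenyl to 3-methoxyphenyl on the aromatic nitrogen reads a 1.0-fold lower number from compound 2 to compound 4 (0.00 log units; within the scatter), which gives the first comparison with a number at both ends at this position. Until now the set held a single number, which could not show whether the place of the methoxy group on this aryl ring matters; for these two groups, the read-out does not tell them apart. The steps that would involve compound 1 or compound 3 cannot be read, and nothing at hand offers an explanation for the flat result.

On these data alone, what stays open is whether this insensitivity belongs to the position as a whole or only to this pair of methoxyphenyl groups, since both numbers come from aryl groups bearing that one substituent. An aryl group carrying an amine or a carboxylic acid, or a longer alkoxy chain in place of the methoxy group, could show whether the number at this position can be moved at all.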